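A Smaller Group Replaces the Arylamino Substituent

This account rests on a few compounds, and the source may have more. Where it says the series, first, only, none or still open, it means among the compounds named here.

Within the data shown here, compound 2 `Cc1cc(Nc2cccc(Cl)c2)c(S(C)(=O)=O)cc1C(=O)N=C(N)N` stands at the higher end of the two numbers measured so far in a functional assay for inhibition of sodium/hydrogen exchanger (Oryctolagus cuniculus) (on this read-out higher numbers stand for weaker inhibition and lower numbers for stronger inhibition), where compound 2 gives 33 nM. Its nearest neighbour is compound 1 `COc1cc(C)c(C(=O)N=C(N)N)cc1S(C)(=O)=O`, which in this assay gives 16 nM. Among the measured compounds shown here, the only measured step, a 2.1-fold higher number from compound 1 to compound 2 (0.31 log units; beyond the scatter), came from the change of methoxy to (3-chlorophenyl)amino on the aromatic carbon. Compound 3 `Cc1cc(C(F)(F)F)c(S(C)(=O)=O)cc1C(=O)N=C(N)N` takes a different route at that same position: trifluoromethyl in place of (3-chlorophenyl)amino on an aromatic carbon. For the measured compounds named here, no measured step covers trifluoromethyl itself; that one step only shows that this position tolerates a change of substituent within a modest span. One therefore expects the step of a 1.3-fold lower number from compound 2 to compound 3 (0.12 log units; within the scatter) to stay at the edge of the usual scatter, leaning toward a somewhat lower number in this assay. For compound 3 the estimate in this assay is 25 nM, with a range from 8 nM to 80 nM.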

Compound 3, half-maximal inhibitory concentration: 37 nM
For compound 3 the middle estimate is 1.5-fold (0.17 log units) below the measured one, and the stated range covers the measured number.
By their numbers in this assay, from the lowest: compound 1; then compounds 2 and 3 (each within the scatter of the next).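

In this assay, the step of a 1.1-fold higher number from compound 2 to compound 3 (0.05 log units; within the scatter) shows that this position, ortho to a methylsulfonyl group, takes trifluoromethyl about as well as (3-chlorophenyl)amino, so neither the aromatic ring nor the hydrogen-bond donor of the leaving group is needed to hold the number at this level. The step of a 2.3-fold higher number from compound 1 to compound 3 (0.36 log units; beyond the scatter) adds a second replacement of methoxy that ends beyond the scatter, and among these three compounds methoxy alone gives the lowest number. No independent data explain these results.

The compounds shown leave open whether ethoxy or another longer ether chain would match methoxy, or whether the ether oxygen itself matters. They also do not show how a simple amine, a nitrile or a lone chlorine would fare at this position.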